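This account rests on a few compounds, and the source may have more. Where it says the series, first, only, none or still open, it means among the compounds named here.

Compound 3 `COc1cccc(-c2n[nH]cc2N2CCNCC2)c1` gives 269 nM in an assay on isolated protein for binding affinity to 5-hydroxytryptamine receptor 6 (Homo sapiens) (on this read-out lower numbers stand for stronger inhibition and higher numbers for weaker inhibition), the lowest of the two numbers shown; compound 2 `c1ccc(-c2n[nH]cc2N2CCCNCC2)cc1` gives 3480 nM in this assay. Compound 1 `COc1cccc(-c2n[nH]cc2N2CCCNCC2)c1` reaches only the limit of > 10000 nM in this assay (the limit of > 10000 nM in this assay, at which 1 of the 3 values shown sits). Compound 4 `Clc1cccc(-c2n[nH]cc2N2CCNCC2)c1` differs from compound 3 by chloro in place of methoxy on an aromatic carbon. Among the measured compounds shown here, the only measured step touching this position, an at least 2.8-fold lower number from compound 1 to compound 2 (0.45 log units; beyond the scatter), was made on the core of compound 1 and removed the methoxy rather than replacing it with chloro, so it bears on the change only loosely. A step no larger than modest is therefore expected, with a slight lowering of the number more likely than a rise: the estimate for compound 4 is 170 nM in this assay, between 45 nM and 650 nM, that is a 1.6-fold lower number from compound 3 to compound 4 (0.20 log units; within the scatter).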

Compound 4, inhibition constant: 109 nM
Beside the measured number, compound 4's estimate is 1.6-fold (0.19 log units) above it; low and high end bracket the measured number.
By their numbers in this assay, from the lowest: compound 4; then compound 3; then compound 2. At a limit, above all of these: compound 1.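

In this assay, chloro in place of methoxy on the core of compound 3 gives a 2.5-fold lower number from compound 3 to compound 4 (0.39 log units; beyond the scatter). This aromatic carbon therefore takes a replacement for methoxy, not only its removal, and here the number falls modestly. The earlier step at this position started from the core of compound 1, which stands at a limit and not at a number: the limit of > 10000 nM in this assay, at which 1 of the 4 values shown sits.

Going by these compounds, whether fluoro, methyl or trifluoromethyl on this carbon would lower the number further stays open. So does whether chloro would have any such effect on the core of compound 1.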